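Replacing 3-hydroxyazetidin-1-yl with 3-(hydroxymethyl)phenyl

A few compounds are considered here, and "the series" means these few. Any claim that something is new, unique, unknown or untested is made for them only; others in the source may bear on it.

Among the measured compounds shown here, two related compounds have numbers so far in a physicochemical assay for solubility, in phosphate buffer, at pH 7.4; on this read-out lower numbers stand for lower solubility and higher numbers for higher solubility. There, compound 1 `OCC1CCN(c2nccnc2OC2CN(c3cnc4ccccc4n3)C2)CC1` gives 500000 nM. Compound 2 `OC1CN(c2nccnc2OC2CN(c3ccc4ccccc4n3)C2)C1` gives 41000 nM, the lower of the two numbers, and the gap between them lies beyond the usual scatter of repeated measurements. These two compounds differ in more than one place, so their gap does not show what any single change does.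

The next compound, compound 3 `OCc1cccc(-c2nccnc2OC2CN(c3ccc4ccccc4n3)C2)c1`, differs from compound 2 in one place. It has 3-(hydroxymethyl)phenyl in place of 3-hydroxyazetidin-1-yl on an aromatic carbon, next to the ring nitrogen (3-(hydroxymethyl)phenyl in place of 3-hydroxyazetidin-1-yl on an aromatic carbon). For the measured compounds named here, no pair measured so far shows a single change of this kind, so the forecast is a judgement with a wide margin. A moderate fall beyond the scatter is expected in this assay, with an estimated step of a 2.7-fold lower number from compound 2 to compound 3 (0.44 log units; beyond the scatter). For compound 3 the expected value is 15000 nM, with an estimated range from 3000 nM to 60000 nM.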

Compound 3, solubility: 29000 nM
The estimate for compound 3 lay 1.9-fold (0.29 log units) below the measured number, within the range that was stated.
By their numbers in this assay, from the lowest: compounds 3 and 2 (each within the scatter of the next); then compound 1.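

In this assay, putting 3-(hydroxymethyl)phenyl in place of 3-hydroxyazetidin-1-yl gives a small difference (a 1.4-fold lower number from compound 2 to compound 3 (0.15 log units; within the scatter)), so the two compounds cannot be ranked on this read-out. Among the compounds shown here, this is the first single change seen on this aromatic carbon, next to the ring nitrogen, and it shows that here a four-membered non-aromatic ring with a hetero atom and a larger six-membered aromatic ring of carbon only can give values that repeated measurements would not tell apart. Nothing measured here explains why the two groups read so alike.

Both groups carry a hydroxyl, so the compounds shown leave open what plain phenyl, with no hydroxymethyl on the ring, would give at this position in this assay. They also leave open whether a carboxylic acid or an amine in place of that hydroxymethyl, or a longer chain bearing the hydroxyl, would stay as close to compound 2 as compound 3 does.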